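The source may hold more compounds than are shown below. What is called first, only, known or untested is meant among the compounds shown, and "the series" means these compounds.

Measured in a functional assay on HL-60 cells (Homo sapiens) for antiproliferative activity, read by MTT assay, with a stated time of 72 h; on this read-out lower numbers stand for stronger inhibition and higher numbers for weaker inhibition:
- Compound 1 `C/C=C1/[C@H](O[C@@H]2O[C@H](COC(C)=O)[C@@H](OC(C)=O)[C@H](OC(C)=O)[C@H]2OC(C)=O)OC=C(C(=O)OC)[C@H]1CC(=O)OCCCCCCCCCCCCCCC`: 8000 nM
- Compound 2 `C/C=C1/[C@H](O[C@@H]2O[C@H](CO)[C@@H](O)[C@H](O)[C@H]2O)OC=C(C(=O)OC)[C@H]1CC(=O)OCCc1ccc(O)c(O)c1`: 54300 nM

Of these two compounds, compound 2 has the higher number, at 54300 nM, and therefore shows the weaker inhibition. The gap to compound 1 lies beyond the usual scatter.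

Compound 3 `C/C=C1/[C@H](O[C@@H]2O[C@H](CO)[C@@H](O)[C@H](O)[C@H]2O)OC=C(C(=O)OC)[C@H]1CC(=O)OCCc1ccccc1` has not yet been measured. Its structure departs from that of compound 2 in one place: phenyl in place of 3,4-dihydroxyphenyl on a saturated chain carbon, two bonds along the chain from an oxygen next to a carbonyl group.

Going by the values given here, no measured pair differs in only one place, so the data offer no direct precedent for this change. The closest measured reference is compound 2 at 54300 nM. In this assay, a small move toward a lower number is expected, about the size of the usual scatter and not clearly beyond it. The expected change is a 1.8-fold lower number from compound 2 to compound 3 (0.26 log units; within the scatter). For compound 3 the estimated value is 30000 nM, with an expected range from 10000 nM to 90000 nM.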

Compound 3, half-maximal inhibitory concentration: 10300 nM
Beside the measured number, compound 3's estimate is 2.9-fold (0.46 log units) above it, and the stated range covers the measured number.
By their numbers in this assay, from the lowest: compounds 1 and 3 (each within the scatter of the next); then compound 2.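

In this assay, phenyl in place of 3,4-dihydroxyphenyl on a saturated chain carbon, two bonds along the chain from an oxygen next to a carbonyl group, gives a 5.3-fold lower number from compound 2 to compound 3 (0.72 log units; beyond the scatter), a modest step beyond the scatter. Going by these compounds alone, this is the first comparison that isolates a single place, since compound 1 differs from compound 2 in more than one, and it shows that the number at this position responds to the ring's substitution and that the two hydroxyl groups are not needed for the activity seen here, as the unsubstituted phenyl of compound 3 gives the lower number. Nothing measured here accounts for the size of this step.

From the compounds shown here alone, it remains open whether a phenyl ring carrying a single hydroxyl group, a methoxy group or a fluorine would fall nearer to compound 2 or to compound 3, and so whether one hydroxyl group alone accounts for the step. Going by these compounds, it is equally open whether the same change would give a step of similar size on a core carrying the acetate groups of compound 1, or with a longer chain between the ring and the ester oxygen.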